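A few compounds are considered here, and "the series" means these few. Any claim that something is new, unique, unknown or untested is made for them only; others in the source may bear on it.

Working notes on the series. In a functional assay on HeLa cells (Homo sapiens) for antiproliferative activity, read by MTT assay, with a stated time of 72 h (on this read-out higher numbers stand for weaker inhibition and lower numbers for stronger inhibition), compound 1 `COc1cc(C(=O)c2sc3ccccc3c2Nc2ccccc2)cc(OC)c1OC` gives 2700 nM. Compound 2 `COc1cc(C(=O)c2sc3ccccc3c2Nc2ccc(C)cc2)cc(OC)c1OC` gives 3500 nM, so the two numbers lie within the scatter of each other and neither stands apart. The next structure is compound 3 `COc1ccc(Nc2c(C(=O)c3cc(OC)c(OC)c(OC)c3)sc3ccccc23)cc1`, which differs from compound 2 by methoxy in place of methyl on an aromatic carbon, para to a large group. Among the compounds with values here, only one measured step bears on this place, namely a 1.3-fold higher number from compound 1 to compound 2 (0.11 log units; within the scatter), for methyl in place of hydrogen on an aromatic carbon. Within the data shown here, that single step sets no trend, and no methoxy compound has yet been measured. No step beyond the scatter is therefore expected in this assay, in either direction. The expected change is a 1.1-fold lower number from compound 2 to compound 3 (0.04 log units; within the scatter). For compound 3 the estimated value is 3200 nM, with an expected range of 1300 nM to 8000 nM.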

Compound 3, half-maximal inhibitory concentration: 7700 nM
Compound 3: middle estimate off by 2.4-fold (0.38 log units), on the low side, within the range that was stated.
By their numbers in this assay, from the lowest: compounds 1 and 2 (each within the scatter of the next); then compound 3.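

In this assay, the aromatic carbon para to a large group proves sensitive to what it carries: methoxy in place of methyl gives a 2.2-fold higher number from compound 2 to compound 3 (0.34 log units; beyond the scatter), and methoxy in place of hydrogen gives a 2.9-fold higher number from compound 1 to compound 3 (0.46 log units; beyond the scatter). Within the data shown here, both steps are modest but beyond the scatter, whereas methyl in place of hydrogen at this carbon stayed within it, so methoxy is the first group here to move the number, and it moves it toward weaker inhibition. No measurement at hand bears on the origin of these steps.

The compounds shown leave open whether this shift is particular to methoxy or also appears with other groups on this carbon, such as fluorine, hydroxyl or an amine. They also leave open whether methoxy on another carbon of the same ring would produce a similar step.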